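Cyclobutylcarbamoyl in place of (pyrrolidin-1-yl)methyl on the side chain

The source may hold more compounds than are shown below. What is called first, only, known or untested is meant among the compounds shown, and "the series" means these compounds.

Compound 1 `CC(=O)OCC[C@@H]1C[C@@H](c2ccc(F)c(F)c2)[C@H](NC(=O)c2cc(-c3c(Cl)cnn3C)c(Cl)o2)CN1` gives 3.4 nM in an assay for inhibition of RAC-alpha serine/threonine-protein kinase (Homo sapiens), read by HTRF, with a stated time of 1 h; a lower number here means a stronger inhibitor, a higher number a weaker inhibitor. Compound 2 `Cn1ncc(Cl)c1-c1cc(C(=O)N[C@@H]2CN[C@H](CCN3CCCC3)C[C@H]2c2ccc(Cl)c(Cl)c2)oc1Cl` gives 6.41 nM, the highest of the three numbers; compound 1 sits within the scatter of it, while compound 3 `CNC(=O)C[C@@H]1C[C@@H](c2ccc(F)c(F)c2)[C@H](NC(=O)c2cc(-c3c(Cl)cnn3C)c(Cl)o2)CN1`, with 1.37 nM, lies beyond it. For the measured compounds named here, the only measured step at the same place is a 2.5-fold lower number from compound 1 to compound 3 (0.39 log units; beyond the scatter), which brought in methylcarbamoyl. Compound 4 `Cn1ncc(Cl)c1-c1cc(C(=O)N[C@@H]2CN[C@H](CC(=O)NC3CCC3)C[C@H]2c2ccc(Cl)c(Cl)c2)oc1Cl` differs from compound 2 by cyclobutylcarbamoyl in place of (pyrrolidin-1-yl)methyl on a saturated chain carbon bound to a saturated ring carbon. Again a carbamoyl group enters on a saturated chain carbon bound to a saturated ring carbon, but no measured step removes (pyrrolidin-1-yl)methyl, so the one comparable step is only a rough guide. A modest move to a lower number is expected, a 1.8-fold lower number from compound 2 to compound 4 (0.26 log units; within the scatter). Compound 4 is estimated at 3.5 nM, within 1.5 nM to 9 nM.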

Compound 4, half-maximal inhibitory concentration: 7.98 nM
Estimate against measurement, compound 4: 2.3-fold (0.36 log units) below; measured number inside the range.
By their numbers in this assay, from the lowest: compound 3; then compounds 1, 2 and 4 (each within the scatter of the next, the first and the last beyond it).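

Cyclobutylcarbamoyl and (pyrrolidin-1-yl)methyl read alike at this position, with a 1.2-fold higher number from compound 2 to compound 4 (0.10 log units; within the scatter) as the step, so the pyrrolidine ring is not required to hold a value in this range. The move to a lower number seen when methylcarbamoyl entered does not recur with this carbamoyl group, although the group leaving was a different one. Nothing available explains this result.

On these data alone, whether methylcarbamoyl would behave differently from cyclobutylcarbamoyl on the core of compound 2 remains open. So does the outcome with a carboxylic acid or an open-chain dimethylamino group on this side chain.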